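A Shorter Acid Side Chain in Place of Isopropyl

The compounds below may be only part of what the source reports. "The series", "measured", "known", "first", "only" and "open" are said of these compounds alone.

Compound 2 `CC(C)[C@H](NC(=O)CN(c1nc(Cl)nc2[nH]cnc12)C1CC1)C(=O)O` gives 31.2% in a functional assay on the whole organism (Tail, strain ICR) with Mus musculus as the target, in the tail flick test, with a stated time of 30 min, at a dose of 25 umol/kg by the oral route; on this read-out higher numbers stand for a stronger effect at the one dose given and lower numbers for a weaker effect; this is the higher of the two measured numbers, but its gap to compound 1 `O=C(O)CC[C@H](NC(=O)CN(c1nc(Cl)nc2[nH]cnc12)C1CC1)C(=O)O`, which gives 26.8%, is within the scatter. Compound 3 `O=C(O)C[C@H](NC(=O)CN(c1nc(Cl)nc2[nH]cnc12)C1CC1)C(=O)O` is compound 2 with one change: carboxymethyl in place of isopropyl on a saturated chain carbon bound to an amide-type nitrogen and a carbonyl carbon. Among the compounds with values here, the one measured step bearing on it is a number 4.4 percentage points higher from compound 1 to compound 2 (within the scatter), where 2-carboxyethyl gave way to isopropyl. Returning an acid-bearing group, now carboxymethyl, is therefore expected to shift the number little, a step of a number 3.2 percentage points lower from compound 2 to compound 3 (within the scatter). Compound 3 is estimated at 28%, within 15% to 42%.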

Compound 3, a percentage reported as activity, at one dose (the size of the read-out at that dose, not a potency): 19.9%
Estimate against measurement, compound 3: 8.1 percentage points above; the measured number falls inside the stated range.
By their numbers in this assay, from the lowest: compounds 3, 1 and 2 (each within the scatter of the next, the first and the last beyond it).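

In this assay, within the data shown here, carboxymethyl in place of isopropyl is the first change at this position to reach beyond the scatter, with a number 11.3 percentage points lower from compound 2 to compound 3 (beyond the scatter) on this one dose. Against the longer 2-carboxyethyl, carboxymethyl gives a number 6.9 percentage points lower from compound 1 to compound 3 (within the scatter), so these numbers do not separate the two acid chains from each other. Nothing available explains either step.

Open, going by these compounds, is how a plain methyl, a primary amide or an amine would read on this same carbon. Also open, on these data alone, is whether a carboxylic acid on a longer chain would read any differently.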